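From Trichlorophenyl to Methylphenyl on a Shared Core

The compounds below may be only part of what the source reports. "The series", "measured", "known", "first", "only" and "open" are said of these compounds alone.

For the measured compounds named here, in a functional assay on HL-60 cells (Homo sapiens) for antiproliferative activity, read by MTT assay, with a stated time of 72 h (on this read-out lower numbers stand for stronger inhibition and higher numbers for weaker inhibition), compound 1 `NC1=NC2(CCOCC2)N(OCCCOc2ccc(Cl)c(Cl)c2)C(N)=N1` gives 1240 nM and compound 2 `NC1=NC2(CCOCC2)N(OCCCOc2cc(Cl)c(Cl)cc2Cl)C(N)=N1` gives 2360 nM, so compound 2 stands within the scatter of its only measured neighbour. Compound 3 `Cc1ccc(OCCCON2C(N)=NC(N)=NC23CCOCC3)cc1` differs from compound 2 by 4-methylphenyl in place of 2,4,5-trichlorophenyl on an oxygen on a saturated carbon. Going by the values given here, the one measured step that bears on this change, chloro in place of hydrogen on an aromatic carbon, is a 1.9-fold higher number from compound 1 to compound 2 (0.28 log units; within the scatter). That single small step is thin evidence for a larger swap, but it points to no clear shift. The step expected in this assay is a 1.2-fold lower number from compound 2 to compound 3 (0.07 log units; within the scatter), so none beyond the scatter. For compound 3 the estimated value is 2000 nM, with an expected range of 800 nM to 5000 nM.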

Compound 3, half-maximal inhibitory concentration: 2580 nM
For compound 3 the middle estimate is 1.3-fold (0.11 log units) below the measured one; the range from low to high includes it.
By their numbers in this assay, from the lowest: compounds 1, 2 and 3 (each within the scatter of the next, the first and the last beyond it).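

In this assay, 4-methylphenyl in place of 2,4,5-trichlorophenyl on this oxygen-linked chain leaves the number within the scatter (a 1.1-fold higher number from compound 2 to compound 3 (0.04 log units; within the scatter)). For the compounds shown here, the same group in place of 3,4-dichlorophenyl gives the first step at this position that goes beyond the scatter, though only modestly (a 2.1-fold higher number from compound 1 to compound 3 (0.32 log units; beyond the scatter)). Nothing measured here explains either step. Still open, from the compounds shown here alone, is how a ring with a single chlorine, such as 4-chlorophenyl, would compare on the shared core. An amine or a carboxylic acid at this place is also untested among the compounds shown.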